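A few compounds are considered here, and "the series" means these few. Any claim that something is new, unique, unknown or untested is made for them only; others in the source may bear on it.

Of the compounds shown here, three with a shared core have been read in a functional assay on A549 cells (Homo sapiens) for antiproliferative activity, read by MTT assay, with a stated time of 72 h; a lower number here means a stronger inhibitor, a higher number a weaker inhibitor. Compound 1 `COc1cc(-n2cnc3ccc(-c4cccc(F)c4)cc32)cc(OC)c1OC` gives 5270 nM, and compound 2 `COc1cc(-n2cnc3ccc(-c4cccc(C)c4C)cc32)cc(OC)c1OC` gives 9250 nM. Compound 3 `COc1cc(-n2cnc3ccc(-c4ccc(Cl)cc4)cc32)cc(OC)c1OC` reaches only a limit of the assay, > 10000 nM, and has no number of its own. Compound 4 `COc1cc(-n2cnc3ccc(-c4ccc(O)cc4)cc32)cc(OC)c1OC` departs from compound 3 in one place: hydroxy in place of chloro on an aromatic carbon. This puts hydroxy in place of chloro on an aromatic carbon, turning 4-chlorophenyl into 4-hydroxyphenyl. The measured steps that bear on this change all swap the aryl group at that part of the core: an at least 1.8-fold higher number from compound 1 to compound 3 (0.27 log units; that floor lies within the scatter), a 1.8-fold higher number from compound 1 to compound 2 (0.24 log units; within the scatter) and an at least 1.0-fold higher number from compound 2 to compound 3 (0.03 log units; that floor lies within the scatter). All three lie within the scatter, although two of them are only floors. None of them involves hydroxy, so the data offer no direction. No step beyond the scatter is therefore expected in this assay, and compound 4 is expected to sit close to compound 2 at 9250 nM. The expected change is an at least 1.2-fold lower number from compound 3 to compound 4 (0.09 log units; that floor lies within the scatter). For compound 4 the estimate is 8000 nM, with an expected range of 3000 nM to 15000 nM.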

Compound 4, half-maximal inhibitory concentration: 5090 nM
Beside the measured number, compound 4's estimate is 1.6-fold (0.20 log units) above it; measured number inside the range.
By their numbers in this assay, from the lowest: compounds 4, 1 and 2 (each within the scatter of the next). At a limit, above all of these: compound 3.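

With hydroxy in place of chloro, the 4-substituted phenyl group gains a number of its own in this assay, and the change reads as an at least 1.9-fold lower number from compound 3 to compound 4 (0.29 log units; that floor lies within the scatter). From the compounds shown here alone, this step is only a floor, and its true size stays unknown, since compound 3 sits at a limit of the assay: the limit of > 10000 nM in this assay, at which 1 of the 4 values shown sits. Against the other aryl groups the result reads as a 1.8-fold lower number from compound 2 to compound 4 (0.26 log units; within the scatter) and as a 1.0-fold lower number from compound 1 to compound 4 (0.02 log units; within the scatter), so the three aryl groups that have numbers cannot be told apart in this assay.

The compounds shown do not tell whether an amine or a carboxylic acid in the place of the hydroxy would stay with compound 4 or reach a limit as compound 3 does. With no step shown beyond the scatter, no group at this position can yet be ranked.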